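The source may report more compounds than this note shows. Statements on the series, on what has been measured and on what is new or still open speak of the compounds shown alone.

Measured so far:
- compound 1 `Oc1ccc(/C=N/Nc2nc3ccccc3s2)cc1O` gives 13600 nM in a functional assay on HL-60 cells (Homo sapiens) for cytotoxicity, read by MTT assay, with a stated time of 72 h; on this read-out lower numbers stand for stronger inhibition and higher numbers for weaker inhibition
- compound 2 `Oc1cccc(/C=N/Nc2nc3ccccc3s2)c1O` gives 350 nM in this assay

Among the measured compounds shown here, compound 1 has the highest number of the two; the only comparison available is with compound 2, whose number is far lower, a gap that lies well beyond the usual scatter. For the measured compounds named here, no pair differing in a single place has been measured, so no direct step size is known for this series.

Compound 3 `Oc1ccc(/C=N/Nc2nc3ccccc3s2)cc1` has not yet been measured in this assay. It differs from compound 1 in one place hydrogen in place of hydroxy on an aromatic carbon, on a six-membered aromatic ring of carbon only, ortho to a hydroxy group and meta to a large group. Going by the values given here, with no measured step for a change of this kind, the step from compound 1 is expected to be small, of either direction, and likely within the scatter. For compound 3 the estimate is 12000 nM, with a range from 2500 nM to 50000 nM, which corresponds to an expected step of a 1.1-fold lower number from compound 1 to compound 3 (0.05 log units; within the scatter).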

Compound 3, half-maximal inhibitory concentration: 4600 nM
Compound 3: middle estimate off by 2.6-fold (0.42 log units), on the high side; the measured number falls inside the stated range.
By their numbers in this assay, from the lowest: compound 2; then compound 3; then compound 1.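

In this assay, among the compounds shown here, the first measured single-place step replaces hydroxy with hydrogen on an aromatic carbon, ortho to a hydroxy group and meta to a large group, and gives a 3.0-fold lower number from compound 1 to compound 3 (0.47 log units; beyond the scatter). This hydroxy is therefore not required for the activity of compound 3, and its loss goes with modestly stronger inhibition on this read-out rather than with weaker inhibition.

On these data alone, it remains open whether a methoxy group or a fluorine atom at this place would give a step of similar size and direction. As far as these compounds go, it is also open how the number would move if the hydroxy remaining in compound 3 gave way to hydrogen or an amine. No measurement at hand bears on the reason for this step.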